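From Ethyl to Butyl: Compound 3 to Compound 4

A few compounds are considered here, and "the series" means these few. Any claim that something is new, unique, unknown or untested is made for them only; others in the source may bear on it.

Compound 3 `CCNC(=O)Nc1nc2ccc(NC(=O)c3c(Cl)cccc3Cl)cc2s1` gives 0.032 ug/mL in a functional assay on WI-38 VA13 cells (Homo sapiens) for cytotoxicity; on this read-out lower numbers stand for an effect already at smaller amounts and higher numbers for an effect only at larger amounts of compound. Among the two numbers in hand it stands highest; its nearest neighbour is compound 1 `CC(C)CC(=O)Nc1nc2ccc(NC(=O)c3c(Cl)cccc3Cl)cc2s1`, which in this assay gives 0.012 ug/mL, a gap described by a 2.7-fold higher number from compound 1 to compound 3 (0.43 log units; beyond the scatter). Compound 2 `O=C(O)CCC(=O)Nc1nc2ccc(NC(=O)c3c(Cl)cccc3Cl)cc2s1` reaches only a limit in this assay, namely > 6.6 ug/mL, as noted in the limit of > 6.6 ug/mL in this assay, at which 1 of the 3 values shown sits. The step of an at least 550-fold higher number from compound 1 to compound 2 (2.74 log units; beyond the scatter) and the step of an at least 200-fold lower number from compound 2 to compound 3 (2.31 log units; beyond the scatter) are both large.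

Compound 4 `CCCCNC(=O)Nc1nc2ccc(NC(=O)c3c(Cl)cccc3Cl)cc2s1` differs from compound 3 by ethyl in place of hydrogen on a saturated chain carbon, two bonds along the chain from an amide-type nitrogen. For the measured compounds named here, no measured step alters this chain in the same way. Going by the values given here, the steps that bear on it show that a neutral change on the chain, as in a 2.7-fold higher number from compound 1 to compound 3 (0.43 log units; beyond the scatter), is modest, whereas the large steps of an at least 550-fold higher number from compound 1 to compound 2 (2.74 log units; beyond the scatter) and an at least 200-fold lower number from compound 2 to compound 3 (2.31 log units; beyond the scatter) involve the 2-carboxyethyl group, which compound 4 does not carry. A small step is therefore expected, estimated as a 1.5-fold lower number from compound 3 to compound 4 (0.16 log units; within the scatter). Compound 4 is expected to give 0.022 ug/mL in this assay, with a range from 0.006 ug/mL to 0.08 ug/mL.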

Compound 4, half-maximal effective concentration: 0.028 ug/mL
For compound 4 the middle estimate is 1.3-fold (0.10 log units) below the measured one, and the stated range covers the measured number.
By their numbers in this assay, from the lowest: compound 1; then compounds 4 and 3 (each within the scatter of the next). At a limit, above all of these: compound 2.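

Ethyl in place of hydrogen at this saturated chain carbon gives no separable difference in this assay, with a 1.1-fold lower number from compound 3 to compound 4 (0.06 log units; within the scatter), so the urea-type side chain can be extended from ethylamino to butylamino without a readable shift. Butylamino stays apart from isobutyl on the carbonyl carbon, with a 2.3-fold higher number from compound 1 to compound 4 (0.37 log units; beyond the scatter), a modest gap like the one printed for ethylamino, and compound 1 keeps the lowest number of the series. Compound 2 remains at a limit, so an at least 230-fold lower number from compound 2 to compound 4 (2.37 log units; beyond the scatter) gives only a bound on a large step: the limit of > 6.6 ug/mL in this assay, at which 1 of the 4 values shown sits.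

As far as these compounds go, it remains open whether a longer chain such as hexylamino, or a ring such as phenylamino, would stay close to compound 4 in this assay. Also open, from the compounds shown here alone, is what a carboxylic acid or an amine carried on the butylamino chain would do.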